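This account rests on a few compounds, and the source may have more. Where it says the series, first, only, none or still open, it means among the compounds named here.

Measured so far in an ADME assay on Vero cells (Chlorocebus sabaeus) for cytotoxicity, read by resazurin assay, with a stated time of 72 h; on this read-out higher numbers stand for lower toxicity in this test and lower numbers for higher toxicity in this test:
- compound 1 `CC(=O)OC[C@H]1O[C@@H](CC(=O)/C=C2\C(=O)N(Cc3cccc(C)c3)c3ccccc32)[C@H](OC(C)=O)[C@@H](OC(C)=O)[C@@H]1OC(C)=O`: 72500 nM
- compound 2 `CC(=O)OC[C@H]1O[C@@H](CC(=O)/C=C2\C(=O)N(Cc3ccccc3)c3ccc(Cl)cc32)[C@H](OC(C)=O)[C@@H](OC(C)=O)[C@@H]1OC(C)=O`: 91200 nM

Compound 2 holds the higher of the two numbers, but compound 1 sits within the scatter of it, so no order is read between them. Compound 3 `CC(=O)OC[C@H]1O[C@@H](CC(=O)/C=C2\C(=O)N(Cc3cccc(C)c3)c3ccc(Cl)cc32)[C@H](OC(C)=O)[C@@H](OC(C)=O)[C@@H]1OC(C)=O` differs from compound 2 by methyl in place of hydrogen on an aromatic carbon. Among the compounds with values here, no step between measured compounds covers this change; compound 1, which carries the same 3-methylbenzyl group, gives a number close to that of compound 2. For compound 3 the expected step is a 1.1-fold lower number from compound 2 to compound 3 (0.03 log units; within the scatter), none beyond the scatter. Compound 3 is expected near 85000 nM, in the range 40000 nM to 180000 nM.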

Compound 3, half-maximal cytotoxic concentration: 91000 nM
Compound 3: middle estimate off by 1.1-fold (0.03 log units), on the low side; the measured number falls inside the stated range.
By their numbers in this assay, from the lowest: compounds 1, 3 and 2 (each within the scatter of the next).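

In this assay the methyl on the aromatic carbon, benzyl to 3-methylbenzyl, now has a direct reading: a 1.0-fold lower number from compound 2 to compound 3 (0.00 log units; within the scatter) with the chloro group present. The chloro group, with the 3-methylbenzyl group present, also has one: a 1.3-fold higher number from compound 1 to compound 3 (0.10 log units; within the scatter) so neither single change separates its pair on this read-out. No measurement at hand offers an explanation for these readings. Still open, from the compounds shown here alone, is how a larger change at this position would read, such as an amine or a carboxylic acid in place of the methyl. Also open, going by these compounds, is whether hydroxyl groups in place of the acetates would leave the number within the scatter.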